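Amide substituent change from phenyl to cyclohexyl

This account rests on a few compounds, and the source may have more. Where it says the series, first, only, none or still open, it means among the compounds named here.

Compound 2 `N[C@H]1CC[C@H](Nc2c(C(=O)Nc3ccccc3)nc(Br)c3cccnc23)CC1` carries a phenyl group on the amide-type nitrogen. Among the measured compounds shown here, in a functional assay on MDA-MB-435 cells (Homo sapiens) for cytotoxicity, read by MTT assay, with a stated time of 72 h (on this read-out lower numbers stand for stronger inhibition and higher numbers for weaker inhibition), compound 2 gives 1000 nM, the only numerical value in this set. Compound 1 `N[C@H]1CC[C@H](Nc2c(C(=O)NCc3ccco3)nc(Br)c3cccnc23)CC1`, with a (furan-2-yl)methyl group at the same position, gives > 10000 nM in this assay, which is a limit of the assay and not a number, and this is the limit (the limit of > 10000 nM in this assay, at which 1 of the 2 values shown sits). The step to the phenyl amide gives an at least 10-fold lower number from compound 1 to compound 2 (1.00 log units; beyond the scatter).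

Compound 3 `N[C@H]1CC[C@H](Nc2c(C(=O)NC3CCCCC3)nc(Br)c3cccnc23)CC1` differs from compound 2 by cyclohexyl in place of phenyl on an amide-type nitrogen. For the measured compounds named here, no measured step covers a change from an aromatic to a non-aromatic ring at this position; the one step recorded changes both ring type and a methylene link at once, so it bears only loosely on the present change. The expected step is therefore a 2.5-fold higher number from compound 2 to compound 3 (0.40 log units; beyond the scatter), a modest weakening that may stay within the scatter. Compound 3 is estimated at 2500 nM in this assay, within a range from 700 nM to 10000 nM.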

Compound 3, half-maximal inhibitory concentration: > 10000 nM
Compound 3 ended at the assay's limit; the forecaster's own chance of this, stated with the estimate: 25%; middle value at least 4.0-fold (0.60 log units) away from the limit.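

Ring type on the amide-type nitrogen matters on its own: with a six-membered carbon ring kept and only aromatic phenyl exchanged for non-aromatic cyclohexyl, this assay shows an at least 10-fold higher number from compound 2 to compound 3 (1.00 log units; beyond the scatter). The earlier step changed ring type and a methylene link together, so it could not show this. Compound 3 gives > 10000 nM, which is a limit of the assay and not a number. Of the three amides, only compound 2 keeps a measured number, the step between compound 1 and compound 3 cannot be read, and those two share one limit: the limit of > 10000 nM in this assay, at which 2 of the 3 values shown sit.

On these data alone, it remains open whether the phenyl ring is the best group at this position or whether substitution on it can lower the number further. A benzyl group on the amide-type nitrogen would separate the methylene link from the ring type, while a pyridyl ring or a methoxy group on the phenyl would show how much change the aromatic ring tolerates in this series.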